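The source may hold more compounds than are shown below. What is called first, only, known or untested is meant among the compounds shown, and "the series" means these compounds.

Of the compounds shown here, three have been measured in an assay on isolated protein for binding affinity to vitamin D3 receptor (Homo sapiens), read by fluorescence polarization, tested at 1 uM; on this read-out higher numbers stand for more inhibition at the one concentration tested (going by the name of the read-out) and lower numbers for less inhibition. Compound 1 `CCN(CC)CCNC(=O)C1CC(C(CC)(CC)c2ccc(C#CC(C)(O)CC)c(C)c2)=CN1CC` gives 59.2%; compound 2 `CCCC(O)(C#Cc1ccc(C(CC)(CC)C2=CN(CC)C(C(=O)NCCN(CC)CC)C2)cc1C)CCC` gives 51.1%; compound 3 `CCN(CC)CCNC(=O)C1CC(C(CC)(CC)c2ccc(C#CC(O)C3CCC3)c(C)c2)=CN1CC` gives 49.3%. The steps among them, a number 8.1 percentage points lower from compound 1 to compound 2 (within the scatter), a number 9.9 percentage points lower from compound 1 to compound 3 (within the scatter) and a number 1.8 percentage points lower from compound 2 to compound 3 (within the scatter), all stay within the scatter. Compound 3 thus stands lowest of the three numbers, nearest compound 2 and furthest from compound 1, but with no gap beyond the scatter to either.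

Compound 4 `CCN(CC)CCNC(=O)C1CC(C(CC)(CC)c2ccc(CCC(O)(CC)CC)c(C)c2)=CN1CC` is not yet measured. The change from compound 3 is a group of 8 heavy atoms (7 carbon, 1 oxygen; no ring) in place of a group of 8 heavy atoms (7 carbon, 1 oxygen; one four-membered non-aromatic ring of carbon only), on an aromatic carbon. All three measured steps vary the group on the triple-bonded carbon and leave the triple bond in place; the change to compound 4 instead takes the triple bond out, so none of them bears directly on it. What the measured steps do show is that varying the group at this end of the molecule has so far moved the number by less than the scatter. No step beyond the scatter is expected, and the expected step is a number 0.7 percentage points higher from compound 3 to compound 4 (within the scatter). No comparison of the same kind is available, so the range is set wide. For compound 4 in this assay the estimate is 50%, with a range from 30% to 68%.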

Compound 4, a percentage reported as inhibition, at one concentration (the size of the read-out at that concentration, not a potency): 35.9%
Estimate against measurement, compound 4: 14.1 percentage points above; the range from low to high includes it.
By their numbers in this assay, from the lowest: compound 4; then compounds 3, 2 and 1 (each within the scatter of the next).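

In this assay, within the data shown here, the group on the aromatic carbon, para to a large group, now moves the number beyond the scatter, which no step among compound 1, compound 2 and compound 3 did: (a number 13.4 percentage points lower from compound 3 to compound 4 (beyond the scatter)), (a number 15.2 percentage points lower from compound 2 to compound 4 (beyond the scatter)) and (a number 23.3 percentage points lower from compound 1 to compound 4 (beyond the scatter)). The 3-ethyl-3-hydroxypentyl group of compound 4 is the only group shown without the triple bond, and no compound shown goes against the link between its absence and the lower number. No measured evidence bears on the reason for this fall.

No compound shown pairs the triple bond with the end carrying the two ethyl groups of compound 4, so the fall cannot yet be assigned to the loss of the triple bond alone. Also open, going by these compounds, is how a double bond in the link, or an amine in place of the hydroxyl, would read here.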